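Notes: 1H-indazol-6-yl in place of 5-bromothiophen-2-yl

The compounds below may be only part of what the source reports. "The series", "measured", "known", "first", "only" and "open" are said of these compounds alone.

Of the compounds shown here, two have numbers so far. In an ADME assay on A549 cells (Homo sapiens) for cytotoxicity, read by resazurin assay, with a stated time of 48 h (a lower number here means that less compound is tolerated, a higher number that more compound is tolerated), compound 1 (`CN(C)c1ccc(CNc2ccc(NC(=O)c3cc(Cl)ccc3O)c(Cl)c2)cc1`) gives 24500 nM, and compound 2 (`O=C(Nc1ccc(NCc2ccc(Br)s2)cc1Cl)c1cc(Cl)ccc1O`) gives 20700 nM. Compound 2 therefore stands within the scatter of compound 1, with no real separation between the two numbers.

Compound 3 (`O=C(Nc1ccc(NCc2ccc3cn[nH]c3c2)cc1Cl)c1cc(Cl)ccc1O`) keeps the shared core and differs from compound 2 only on a saturated chain carbon bound to a nitrogen on an aromatic ring: 1H-indazol-6-yl in place of 5-bromothiophen-2-yl on a saturated chain carbon bound to a nitrogen on an aromatic ring.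

Among the measured compounds shown here, the only measured step at this place is a 1.2-fold lower number from compound 1 to compound 2 (0.07 log units; within the scatter), with 5-bromothiophen-2-yl in place of 4-(dimethylamino)phenyl. For the measured compounds named here, it is a single step, and no measured compound carries 1H-indazol-6-yl, so the guidance is thin. On that evidence, no step beyond the scatter is expected in this assay. The expected step is a 1.1-fold higher number from compound 2 to compound 3 (0.03 log units; within the scatter). For compound 3 the estimated value is 22000 nM, with an expected range of 10000 nM to 46000 nM.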

Compound 3, half-maximal cytotoxic concentration: 45300 nM
Beside the measured number, compound 3's estimate is 2.1-fold (0.31 log units) below it; the range from low to high includes it.
By their numbers in this assay, from the lowest: compounds 2, 1 and 3 (each within the scatter of the next, the first and the last beyond it).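

In this assay, the place on a saturated chain carbon bound to a nitrogen on an aromatic ring now gives a step beyond the scatter, which the earlier pair did not: 1H-indazol-6-yl in place of 5-bromothiophen-2-yl gives a 2.2-fold higher number from compound 2 to compound 3 (0.34 log units; beyond the scatter), a modest step. Against 4-(dimethylamino)phenyl, the same entering group gives a 1.8-fold higher number from compound 1 to compound 3 (0.27 log units; within the scatter), so the separation holds only against 5-bromothiophen-2-yl, and compound 1 cannot be told apart from either of the other two. Nothing available here connects this step to any measured property of the groups.

The entering group differs from 5-bromothiophen-2-yl in several counted features at once, including its hydrogen-bond donor, its heavy atoms and its ring count, and these compounds do not separate them. An unsubstituted thiophen-2-yl, a plain phenyl or a 1-methyl-1H-indazol-6-yl at this place would bear on that, while a short alkyl chain would show whether an aromatic ring is needed there at all.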